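The source may report more compounds than this note shows. Statements on the series, on what has been measured and on what is new or still open speak of the compounds shown alone.

Among the measured compounds shown here, in a functional assay on HeLa cells (Homo sapiens) for cytotoxicity, read by resazurin assay, with a stated time of 24 h (on this read-out higher numbers stand for weaker inhibition and lower numbers for stronger inhibition), compound 1 (`C[C@H]1O[C@H](O[C@H]2CC[C@H](n3ccc(NC(=O)c4ccc(N)cc4)nc3=O)O[C@@H]2C)[C@H](O)[C@@H](O)[C@@H]1N(C)C`) gives 16 ug/mL, the only actual number so far. Compound 2 (`CC[C@H](C)CCC(=O)Nc1ccn([C@H]2CC[C@H](O[C@H]3O[C@H](C)[C@@H](N(C)C)[C@H](O)[C@H]3O)[C@@H](C)O2)c(=O)n1`) is reported only as a limit, > 64 ug/mL. Replacing 4-aminophenyl with 3-methylpentyl on the carbonyl carbon gives an at least 4.0-fold higher number from compound 1 to compound 2 (0.60 log units; beyond the scatter), which is beyond the scatter. Compound 3 (`C[C@H]1O[C@H](O[C@H]2CC[C@H](n3ccc(NC(=O)c4ccc(F)cc4)nc3=O)O[C@@H]2C)[C@H](O)[C@@H](O)[C@@H]1N(C)C`) keeps the 4-substituted phenyl group and differs from compound 1 at one place, with fluoro in place of amino on an aromatic carbon, para to a large group: fluoro in place of amino on an aromatic carbon. Only the replacement of the whole group has been measured, as an at least 4.0-fold higher number from compound 1 to compound 2 (0.60 log units; beyond the scatter), and the present exchange is smaller, so a smaller step towards weaker inhibition, near the edge of the scatter, is expected in this assay. The expected step is a 2.0-fold higher number from compound 1 to compound 3 (0.30 log units; within the scatter). For compound 3 the estimated value is 32 ug/mL, with an expected range from 12 ug/mL to 64 ug/mL.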

Compound 3, half-maximal inhibitory concentration: > 64 ug/mL
Compound 3 was reported as a limit (the forecaster's own chance of this, stated with the estimate: 25%); middle value at least 2.0-fold (0.30 log units) from the limit.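

In this assay, exchanging amino for fluoro on the aromatic carbon, para to a large group, gives an at least 4.0-fold higher number from compound 1 to compound 3 (0.60 log units; beyond the scatter), so a change at this one place is already enough, without replacing the whole 4-aminophenyl group. Compound 3 gives > 64 ug/mL, which is a limit and not a number. The step between compound 2 and compound 3 cannot be read, and neither compound can be placed ahead of the other: the limit of > 64 ug/mL in this assay, at which 2 of the 3 values shown sit.

The compounds shown leave open how far compound 3 lies past its limit, and so how large this step really is. They also leave open whether the amino group is alone in holding the read-out at this place, or whether a hydroxyl, a methoxy or a dimethylamino group on the same aromatic carbon would do the same.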